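Spiro series: aryl swap on the triazole nitrogen

A few compounds are considered here, and "the series" means these few. Any claim that something is new, unique, unknown or untested is made for them only; others in the source may bear on it.

Three compounds of the series carry numbers in an ADME assay on HUVEC cells (Homo sapiens) for antiproliferative activity, read by MTT assay, with a stated time of 48 h (on this read-out higher numbers stand for weaker inhibition and lower numbers for stronger inhibition), so far. Compound 1 `N#CC1=C(N)Oc2c(c3nc4ccccc4nc3c3ccccc23)C12C(=O)N(Cc1cnnn1-c1cccc(S(N)(=O)=O)c1)c1ccccc12` gives 38600 nM. Compound 2 `N#CC1=C(N)Oc2c(c3nc4ccccc4nc3c3ccccc23)C12C(=O)N(Cc1cnnn1-c1cc(Cl)ccc1Cl)c1ccccc12` gives only a limit of the assay, > 50000 nM. Compound 3 `N#CC1=C(N)Oc2c(N)cc3nc4ccccc4nc3c2C12C(=O)N(Cc1cnnn1-c1ccc(Cl)cc1)c1ccccc12` also gives only a limit of the assay, > 50000 nM. Compound 3 therefore stands at the floor of the read-out, with no number of its own; the same holds for one further value, (the limit of > 50000 nM in this assay, at which 2 of the 3 values shown sit).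

Among the measured compounds shown here, the only measured step at the aromatic nitrogen is an at least 1.2-fold higher number from compound 1 to compound 2 (0.11 log units; that floor lies within the scatter); it swaps one aryl group for another at that position, and its floor lies within the scatter, so it shows no clear effect of such a swap.

Compound 4 `CCc1cccc(CC)c1-n1nncc1CN1C(=O)C2(C(C#N)=C(N)Oc3c(N)cc4nc5ccccc5nc4c32)c2ccccc21` differs from compound 3 in one place: 2,6-diethylphenyl in place of 4-chlorophenyl on an aromatic nitrogen. Neither group of this pair has been measured elsewhere in the series, so the step from compound 1 to compound 2 is the nearest guide, and it gave no change beyond the scatter. Compound 3 sits at a limit, so an estimate for compound 4 can only be a limit as well: compound 4 is expected to give 70000 nM in this assay, within 30000 nM to 200000 nM, which corresponds to an expected step that the limit leaves unreadable from compound 3 to compound 4, none beyond the scatter.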

Compound 4, half-maximal inhibitory concentration: > 50000 nM
Compound 4 gave a limit, no number; the forecaster's own chance of this, stated with the estimate: 85%; the middle value is on the limit's open side.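

Compound 4, like compound 3, gives only a limit in this assay, so no new step can be read between the two: the limit of > 50000 nM in this assay, at which 3 of the 4 values shown sit.

The compounds shown leave open how far the aryl group on the aromatic nitrogen shifts this read-out at all; only compound 1 carries a number rather than a limit.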